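This account rests on a few compounds, and the source may have more. Where it says the series, first, only, none or still open, it means among the compounds named here.

Compound 1 `COc1ccc(N=C2NC(=O)/C(=C\c3ccc(N(C)C)cc3)S2)cc1` is tested in an ADME assay on cells (Homo sapiens) for antiproliferative activity; on this read-out higher numbers stand for weaker inhibition and lower numbers for stronger inhibition. In this assay compound 1 gives > 100000 nM, which is a limit of the assay and not a number. Compound 2 `CC(=O)Nc1ccc(/C=C2/S/C(=N/c3cccc(Cl)c3)NC2=O)cc1` gives > 100000 nM in this assay, which is also a limit. For the measured compounds named here, compound 1 therefore stands with the only other measured compound, at the limit of > 100000 nM in this assay, at which 2 of the 2 values shown sit.

Compound 3 `CN(C)c1ccc(/C=C2/SC(=Nc3ccccc3Cl)NC2=O)cc1` keeps the core of compound 1 but has 2-chlorophenyl in place of 4-methoxyphenyl on a double-bonded nitrogen. Going by the values given here, no measured pair shows what a swap like this does, so the expectation is a cautious one. The step expected a number no higher from compound 1 to compound 3 (the limit leaves the size open) is none beyond the usual scatter, with no direction favoured. For compound 3 the estimated value is 100000 nM, with an expected range from 30000 nM to 300000 nM, and the assay may well report only a limit.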

Compound 3, half-maximal inhibitory concentration: > 100000 nM
Compound 3: only a limit was reported; the forecaster's own chance of this, stated with the estimate: 70%; the middle value sits exactly at the limit.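

In this assay compound 3 gives > 100000 nM, which is a limit and not a number. Compound 1 is also reported only as a limit, so the step from it to compound 3 cannot be read. The compounds shown leave open what their true values are and which change to the shared core would give a measurable number: the limit of > 100000 nM in this assay, at which 3 of the 3 values shown sit.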